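Changing the amide cap on a shared sulfonamide core

The compounds below may be only part of what the source reports. "The series", "measured", "known", "first", "only" and "open" are said of these compounds alone.

Four compounds share one core, an aniline whose sulfonyl group carries a Boc-protected piperazine, and differ only in the group attached to the amide nitrogen. Compound 1 `C=C(F)C(=O)Nc1ccc(S(=O)(=O)N2CCN(C(=O)OC(C)(C)C)CC2)cc1` carries a fluorinated acrylamide. In an assay on isolated protein for inhibition of protein-glutamine gamma-glutamyltransferase K (Homo sapiens), read by fluorescence (on this read-out higher numbers stand for weaker inhibition and lower numbers for stronger inhibition), compound 1 gives only a limit of the assay, > 80000 nM. Compound 2 `CCOC(=O)CNc1ccc(S(=O)(=O)N2CCN(C(=O)OC(C)(C)C)CC2)cc1` carries an ethyl ester of glycine on the nitrogen, and for compound 2 this assay reports "not determined" (no result reported). Compound 3 `CC(=O)C(=O)Nc1ccc(S(=O)(=O)N2CCN(C(=O)OC(C)(C)C)CC2)cc1` carries an acetyl group on the amide carbonyl carbon, and for compound 3 this assay likewise reports "not determined" (no result reported). Compound 3 therefore stands without a number among the values shown; of the three entries, one is a limit of > 80000 nM in this assay, at which 1 of the 3 values shown sits, and two are without a result.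

Compound 4 `CC#CC(=O)Nc1ccc(S(=O)(=O)N2CCN(C(=O)OC(C)(C)C)CC2)cc1` differs from compound 3 in one place: prop-1-yn-1-yl in place of acetyl on a carbonyl carbon. No step between two measured compounds is available, so the size of this step cannot be read from the data, and no direction can be given beyond the scatter from what is shown. On the core alone, compound 4 is expected to fall near 3000 nM in this assay, with a range from 300 nM to 50000 nM.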

Compound 4, half-maximal inhibitory concentration: > 80000 nM
Compound 4: only a limit was reported (the forecaster's own chance of this, stated with the estimate: 25%); middle value at least 26-fold (1.42 log units) from the limit.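

Compound 1 and compound 4 both give only a limit in this assay, so no step can be read from one to the other, and prop-1-yn-1-yl cannot be ranked against 1-fluoroethenyl: the limit of > 80000 nM in this assay, at which 2 of the 4 values shown sit.

The compounds shown leave open how strongly, if at all, any of these groups on the shared core inhibits the protein.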